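The source may hold more compounds than are shown below. What is called first, only, known or untested is meant among the compounds shown, and "the series" means these compounds.

Measured compounds in a functional assay on PC-12 cells (Rattus norvegicus) for cytotoxicity, read by MTT assay, with stated times of 3 h and 2 h, tested at 5 uM; a higher number here means a stronger effect of the compound at the concentration tested, a lower number a weaker effect:
- compound 1, `CC(=O)c1cc2ccc(OCCCCCn3cc(CNC(=O)CCCCC4CCSS4)nn3)cc2oc1=O`, gives 22.2%
- compound 2, `O=C(CCCCC1CCSS1)NCc1cn(CCCCCOc2ccc3cc(-c4ccccc4)c(=O)oc3c2)nn1`, gives 28%
- compound 3, `COc1ccc(-c2cc3ccc(OCCCCCn4cc(CNC(=O)CCCCC5CCSS5)nn4)cc3oc2=O)cc1`, gives 41%

Compound 3 stands highest of the three numbers in this assay, and both of its steps to the others lie beyond the scatter: a number 18.8 percentage points higher from compound 1 to compound 3 (beyond the scatter) and a number 13 percentage points higher from compound 2 to compound 3 (beyond the scatter). Between compound 1 and compound 2 the step of a number 5.8 percentage points higher from compound 1 to compound 2 (within the scatter) is within the scatter, so the two are not ordered.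

Compound 4, `COc1ccc(-c2cc3ccc(OCCCCCn4cc(CNC(=O)CCCCC5CCSS5)nn4)cc3oc2=O)cc1OC`, is not yet measured in this assay. It differs from compound 3 in one place: methoxy in place of hydrogen on an aromatic carbon. Cut one bond further out, the change reads 4-methoxyphenyl to 3,4-dimethoxyphenyl.

Among the compounds with values here, only one measured step bears on this change, methoxy in place of hydrogen on an aromatic carbon, namely a number 13 percentage points higher from compound 2 to compound 3 (beyond the scatter), a modest rise beyond the scatter. Within the data shown here, that methoxy entered a different place on the ring, and no measured pair shows a second methoxy next to a first, so the one step is a weak guide. A small rise, possibly within the scatter, is expected for compound 4: a number 5 percentage points higher from compound 3 to compound 4 (within the scatter). Compound 4 is therefore estimated at 46% in this assay, with a range from 30% to 62%.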

Compound 4, a percentage reported as activity, at one concentration (the size of the read-out at that concentration, not a potency): 46.9%
Beside the measured number, compound 4's estimate is 0.9 percentage points below it, within the range that was stated.
By their numbers in this assay, from the lowest: compounds 1 and 2 (each within the scatter of the next); then compounds 3 and 4 (each within the scatter of the next).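

In this assay, methoxy in place of hydrogen on an aromatic carbon, ortho to a methoxy group, gives a number 5.9 percentage points higher from compound 3 to compound 4 (within the scatter), so the second methoxy cannot be told apart from the 4-methoxyphenyl parent, whereas the earlier methoxy step gave a number 13 percentage points higher from compound 2 to compound 3 (beyond the scatter). The 3,4-dimethoxyphenyl group nevertheless stands clear of both other substituents at this position, with a number 18.9 percentage points higher from compound 2 to compound 4 (beyond the scatter) against phenyl and a number 24.7 percentage points higher from compound 1 to compound 4 (beyond the scatter) against acetyl, placing it in the upper pair of the series alongside 4-methoxyphenyl. No supporting data are available to explain these differences.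

As far as these compounds go, it remains open whether a dimethylamino group or a carboxylic acid on the same aromatic ring would read differently from the methoxy groups, and whether an ethoxy or longer alkoxy chain in place of the added methoxy would separate from the 4-methoxyphenyl parent. From the compounds shown here alone, all of these readings come from a single tested concentration, so how the compounds would order across a range of concentrations also remains open.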